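Hydroxyethoxy to methoxymethoxy: a rearranged side chain

This account rests on a few compounds, and the source may have more. Where it says the series, first, only, none or still open, it means among the compounds named here.

Measured compounds:
- compound 1 `COc1cc(OC)c(OC)cc1C[S+]([O-])c1ncccc1C(=O)Nc1ccncc1`, 0.14 h
- compound 2 `COc1ccc(C[S+]([O-])c2ncccc2C(=O)Nc2ccncc2)c(OCCO)c1`, 1.78 h
- compound 3 `COc1cccc(OC)c1C[S+]([O-])c1ncccc1C(=O)Nc1ccncc1`, 38.5 h

Three compounds share one core and have been run in an ADME assay; on this read-out lower numbers stand for a shorter-lived compound and higher numbers for a longer-lived compound. Compound 1 `COc1cc(OC)c(OC)cc1C[S+]([O-])c1ncccc1C(=O)Nc1ccncc1` gives 0.14 h, compound 2 `COc1ccc(C[S+]([O-])c2ncccc2C(=O)Nc2ccncc2)c(OCCO)c1` gives 1.78 h, and compound 3 `COc1cccc(OC)c1C[S+]([O-])c1ncccc1C(=O)Nc1ccncc1` gives 38.5 h. Compound 2 holds the second highest of the three numbers: its nearest neighbour is compound 1, with a lower number beyond the scatter, and the furthest is compound 3, with a higher number also beyond the scatter. None of these pairs differs in only one place, so no single-point step can be read from them; the three values only show that the series spans a wide range in this assay.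

The next compound, compound 4 `COCOc1cc(OC)ccc1C[S+]([O-])c1ncccc1C(=O)Nc1ccncc1`, is built from the same atoms as compound 2, joined differently: methoxy in place of hydroxymethyl on a saturated chain carbon bound to an oxygen on an aromatic ring. For the measured compounds named here, with no measured single-point step to lean on, the expectation rests on compound 2 alone. The change touches only the side chain, so a step of modest size is expected, a 1.2-fold higher number from compound 2 to compound 4 (0.09 log units; within the scatter), with the direction uncertain and possibly none beyond the scatter. Compound 4 is therefore estimated at 2.2 h, within a range of 0.6 h to 8 h.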

Compound 4, half-life: 8.25 h
Compound 4: the middle estimate sits 3.8-fold (0.57 log units) below what was measured, and the stated range ends below it.
By their numbers in this assay, from the lowest: compound 1; then compound 2; then compound 4; then compound 3.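

In this assay, this pair gives the series its first single-point step: methoxy in place of hydroxymethyl on a saturated chain carbon bound to an oxygen on an aromatic ring gives a 4.6-fold higher number from compound 2 to compound 4 (0.67 log units; beyond the scatter), with the atoms themselves unchanged. The position is therefore sensitive, since rearranging 2-hydroxyethoxy to methoxymethoxy, with the same heavy-atom count and one hydrogen-bond donor fewer, moves the half-life beyond the scatter. Nothing measured alongside these compounds bears on why the step occurs, so it stands as an observation only.

One pair cannot separate the loss of the hydrogen-bond donor from the rearrangement of the chain, and a 2-methoxyethoxy or 2-aminoethoxy chain in the same place would bear on that question. From the compounds shown here alone, it also remains open whether the step carries over to the ring patterns of compound 1 and compound 3, which differ from compound 4 in more than one place and so give no single-point reading.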